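Imidazolyl retinoid ester to 4-hydroxyphenyl amide: expected potency

This account rests on a few compounds, and the source may have more. Where it says the series, first, only, none or still open, it means among the compounds named here.

For the measured compounds named here, compound 1 `COC(=O)/C=C(C)/C=C/C=C(C)/C=C/C1=C(C)C(n2ccnc2)CCC1(C)C` is the only compound of this set with a firm number in a functional assay on T47D cells for inhibition of cytochrome P450 26A1 (Homo sapiens); on this read-out higher numbers stand for weaker inhibition and lower numbers for stronger inhibition: compound 1 gives 215 nM. Its stereodefined counterpart, compound 2 `COC(=O)/C=C(C)/C=C/C=C(C)/C=C/C1=C(C)[C@H](n2ccnc2)CCC1(C)C`, gives 6000 nM; 6000 nM (2 entries) in this assay, the two differing only in that (the fact that one of compounds 1 and 2 is drawn with a defined configuration and the other without, at the place where they differ). For the triazole acid, compound 3 `CC1=C(/C=C/C(C)=C/C=C/C(C)=C/C(=O)O)C(C)(C)CCC1n1cncn1`, the entry in this assay reads "not determined" (no result reported). Compound 4 `CC1=C(/C=C/C(C)=C/C=C/C(C)=C/C(=O)Nc2ccc(O)cc2)C(C)(C)CCC1n1ccnc1` is not yet measured; it differs from compound 1 in (4-hydroxyphenyl)amino in place of methoxy on a carbonyl carbon, in words (4-hydroxyphenyl)amino in place of methoxy on a carbonyl carbon. Going by the values given here, no measured step of this kind exists here, so the expected step from compound 1 to compound 4 is set close to the scatter, a 1.4-fold higher number from compound 1 to compound 4 (0.14 log units; within the scatter), leaning slightly weaker. Compound 4 is therefore estimated at 300 nM in this assay, within 60 nM to 1500 nM.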

Compound 4, half-maximal inhibitory concentration: 24 nM
For compound 4 the middle estimate is 13-fold (1.10 log units) above the measured one; the whole stated range lies above it.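

Replacing methoxy with (4-hydroxyphenyl)amino on the carbonyl carbon gives a 9.0-fold lower number from compound 1 to compound 4 (0.95 log units; beyond the scatter) in this assay, so this position accepts a far larger group carrying an aromatic ring, and inhibition grows stronger. For the compounds shown here, this is the first readable step at this position, since compounds 1 and 2 differ only in how their configuration is drawn. Nothing shown here accounts for the size of the step.

From the compounds shown here alone, how a plain phenylamino group or a methylamino group on this carbonyl carbon would compare stays open. The compounds shown therefore do not separate the share of the hydroxyl from that of the ring or the amide hydrogen.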